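Notes on an M5 modulator series: compound 2 to compound 4

The source may report more compounds than this note shows. Statements on the series, on what has been measured and on what is new or still open speak of the compounds shown alone.

The measured compounds share one core and differ only in the arm attached to it. Compound 1 `O=C1C(=O)N(Cc2ccc(-c3ccncc3)cn2)c2ccc(OC(F)(F)F)cc21` returns only a limit in a functional assay on CHO cells for positive allosteric modulation of muscarinic acetylcholine receptor M5 (Homo sapiens), read by FLIPR and calcium flux, with a stated time of 1 h (a lower number here means that less compound is needed, a higher number that more compound is needed for the effect), namely > 30000 nM. Compound 2 `O=C1C(=O)N(Cc2cccc(Oc3ccccc3)c2)c2ccc(OC(F)(F)F)cc21` likewise returns only a limit in this assay, > 30000 nM. Within the data shown here, compound 3 `O=C1C(=O)N(Cc2ccc(Cl)nc2)c2ccc(OC(F)(F)F)cc21` is the one member that gives a number in this assay, 2400 nM. Compound 2 therefore stands at the limit of > 30000 nM in this assay, at which 2 of the 3 values shown sit, shared with compound 1, and no ordering between compound 1 and compound 2 can be read from these values.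

Compound 4 `O=C1C(=O)N(Cc2cccc(-c3ccccc3)c2)c2ccc(OC(F)(F)F)cc21` differs from compound 2 by phenyl in place of phenoxy on an aromatic carbon. Among the measured compounds shown here, no measured pair isolates this change, so its size is unknown. Since compound 2 sits at the limit, the step from compound 2 to compound 4 is expected to be an at least 1.2-fold lower number from compound 2 to compound 4 (0.07 log units; that floor lies within the scatter), with no clear shift beyond the scatter. The value expected for compound 4 in this assay is 25000 nM, within a range from 8000 nM to 80000 nM, and a limit rather than a number is the more probable outcome.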

Compound 4, half-maximal effective concentration: > 30000 nM
Compound 4: only a limit was reported (the forecaster's own chance of this, stated with the estimate: 60%); middle value at least 1.2-fold (0.07 log units) away from the limit.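

Compound 4 returns only a limit in this assay, > 30000 nM, so no step can be read between compound 2 and compound 4, which both stand at the limit: the limit of > 30000 nM in this assay, at which 3 of the 4 values shown sit. The compounds shown leave open whether phenyl in place of phenoxy changes the value at all.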